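Swapping an amide for a sulfonamide on the piperidine nitrogen

The source may hold more compounds than are shown below. What is called first, only, known or untested is meant among the compounds shown, and "the series" means these compounds.

Compound 1 `O=C(c1ccccc1)N1CCC(NS(=O)(=O)c2cc(S(=O)(=O)c3ccccc3)ccc2C(F)(F)F)CC1` is the starting point. In a physicochemical assay for solubility (a higher number here means a more soluble compound, a lower number a less soluble compound), compound 1 gives 12500 nM. Its nearest measured neighbour is compound 2 `O=C(O)c1cccc(S(=O)(=O)N2CCC(NS(=O)(=O)c3cc(S(=O)(=O)c4ccccc4)ccc3C(F)(F)F)CC2)c1`, which differs only in bearing a (3-carboxyphenyl)sulfonyl in place of benzoyl on an amine nitrogen in a ring; in this assay compound 2 gives 12500 nM, so the step of no change at the digits printed from compound 1 to compound 2 (within the scatter) shows no change within the scatter.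

The unmeasured compound 3 `N#Cc1cccc(S(=O)(=O)N2CCC(NS(=O)(=O)c3cc(S(=O)(=O)c4ccccc4)ccc3C(F)(F)F)CC2)c1` is reached from compound 1 by the change ((3-cyanophenyl)sulfonyl in place of benzoyl on an amine nitrogen in a ring). For the measured compounds named here, the only step that bears on it is the one from compound 1 to compound 2, where a different substituted phenylsulfonyl took the place of the same benzoyl and left this assay unchanged. On that basis no step beyond the scatter is expected, so that a 1.1-fold lower number from compound 1 to compound 3 (0.06 log units; within the scatter) is estimated as flat.

Compound 3 is therefore expected to give about 11000 nM in this assay, between 4500 nM and 27000 nM.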

Compound 3, solubility: 6300 nM
Beside the measured number, compound 3's estimate is 1.7-fold (0.24 log units) above it; the range from low to high includes it.
By their numbers in this assay, from the lowest: compounds 3, 1 and 2 (each within the scatter of the next).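

In this assay, the step to the (3-cyanophenyl)sulfonyl group on the amine nitrogen in a ring gives a 2.0-fold lower number from compound 1 to compound 3 (0.30 log units; within the scatter), so a second substituted phenylsulfonyl also stays within the scatter of benzoyl at this position. Putting cyano in place of carboxy on an aromatic carbon gives a 2.0-fold lower number from compound 2 to compound 3 (0.30 log units; within the scatter), so this read-out does not separate these two substituents, and the three compounds cannot be ranked. No measurement is available that would explain these readings.

The compounds shown leave open whether an amine or a methoxy group on this phenylsulfonyl, or a methanesulfonyl group in place of the whole aryl sulfonyl, would give a step beyond the scatter. They also leave open how an unsubstituted phenylsulfonyl would compare with benzoyl at this nitrogen.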